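Hydroxyethyl Replaces Isopropyl on an Inactive Adenine Isomer

This account rests on a few compounds, and the source may have more. Where it says the series, first, only, none or still open, it means among the compounds named here.

Compound 2 `CC(C)n1cnc2ncnc(N)c21` carries an isopropyl group on a ring nitrogen of a two-ring core. In an assay on CHO cells for displacement of a labelled ligand from adenosine receptor A3 (Homo sapiens) (a lower number here means a stronger inhibitor, a higher number a weaker inhibitor), compound 2 gives > 100000 nM, which is a limit of the assay and not a number. Compound 1 `CC(C)n1cnc2c(N)ncnc21`, the isomer with the same isopropyl group, sits at the same limit, > 100000 nM. Within the data shown here, compound 3 `Nc1ncnc2c1ncn2C1CCC1` gives 33000 nM in this assay, and the only measured step, an at least 3.0-fold lower number from compound 1 to compound 3 (0.48 log units; beyond the scatter), shows a change of ring substituent that is unrelated to the one considered here. The unmeasured compound 4 `Nc1ncnc2ncn(CCO)c12` differs from compound 2 by 2-hydroxyethyl in place of isopropyl on an aromatic nitrogen. Among the measured compounds shown here, no measured step covers a hydroxyethyl group, and the weight of the evidence is the limit of > 100000 nM in this assay, at which 2 of the 3 values shown sit. Compound 4 is therefore expected to stay near that limit, so the step that the limit leaves unreadable from compound 2 to compound 4 is estimated to lie within the scatter. The estimate for compound 4 in this assay is 150000 nM, with a range from 30000 nM to 600000 nM.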

Compound 4, inhibition constant: > 100000 nM
Compound 4 ended at the assay's limit; the forecaster's own chance of this, stated with the estimate: 80%; the middle value does not contradict the limit.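

In this assay compound 4 gives > 100000 nM, a limit of the assay and not a number. Among these compounds, compound 2 also stands at a limit, so no step between compound 2 and compound 4 can be read. The compounds shown leave open what 2-hydroxyethyl in place of isopropyl on an aromatic nitrogen does in this assay.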